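The compounds below may be only part of what the source reports. "The series", "measured", "known", "first", "only" and "open" are said of these compounds alone.

Compound 3 `O=C(C1CCCO1)N1CCc2nc(C#Cc3ccccc3)sc2C1` carries an oxolan-2-yl group on the carbonyl carbon that is joined to the amide-type nitrogen of the shared core. In an assay on HEK293 cells for negative allosteric modulation of metabotropic glutamate receptor 5 (Homo sapiens), read by FLIPR, with a stated time of 1 h (on this read-out higher numbers stand for weaker inhibition and lower numbers for stronger inhibition), compound 3 gives > 10000 nM, which is a limit of the assay rather than a number. Two near relatives stand at the same point. Compound 1 `CC1CC(C(=O)N2CCc3nc(C#Cc4ccccc4)sc3C2)C1`, with a 3-methylcyclobutyl group at that carbonyl carbon, gives > 10000 nM in this assay, again a limit. Compound 2 `COC1CC(C(=O)N2CCc3nc(C#Cc4ccccc4)sc3C2)C1`, with a 3-methoxycyclobutyl group there, gives > 10000 nM, also a limit. The steps between these three cannot be sized: a step that the two limits leave unreadable from compound 1 to compound 3 and a step that the two limits leave unreadable from compound 2 to compound 3 are both unreadable, as is a step that the two limits leave unreadable from compound 1 to compound 2, because of the limit of > 10000 nM in this assay, at which 3 of the 3 values shown sit.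

Compound 4 `CC1CCCC(C(=O)N2CCc3nc(C#Cc4ccccc4)sc3C2)C1` differs from compound 3 in one place: 3-methylcyclohexyl in place of oxolan-2-yl on a carbonyl carbon. The two steps that bear on this change, from a saturated ring on the carbonyl carbon to another, both end at the limit, and the carbon-only ring of compound 1 also gave no measurable inhibition. Among the measured compounds shown here, nothing among the measured compounds points to a readable step in this assay. The step that the limit leaves unreadable from compound 3 to compound 4 is therefore expected to lie within the scatter. Compound 4 is expected to give 15000 nM, with a range from 3000 nM to 60000 nM.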

Compound 4, half-maximal inhibitory concentration: > 10000 nM
Compound 4 gave a limit, no number (the forecaster's own chance of this, stated with the estimate: 75%); the middle value is on the limit's open side.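

In this assay compound 4 gives only a limit, as do compound 1, compound 2 and compound 3, so no step from any of these to compound 4 can be read, for one reason: the limit of > 10000 nM in this assay, at which 4 of the 4 values shown sit. The compounds shown leave open which group on the carbonyl carbon, if any, would give a measurable value.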